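The compounds below may be only part of what the source reports. "The series", "measured", "known", "first", "only" and "open" are said of these compounds alone.

Compound 1 `Cc1nc(-c2ccc(C(F)(F)F)cc2)sc1CNc1ccc(CCCC(=O)O)cc1` gives 44% in a functional assay on CHO cells for agonist activity at Free fatty acid receptor 1 (Homo sapiens), read by a luciferase reporter; a higher number here means a larger maximal response, a lower number a smaller maximal response. Compound 2 `Cc1nc(-c2ccc(C(F)(F)F)cc2)sc1CNc1ccc(OCC(=O)O)cc1` gives 100% in this assay.

Compound 2 stands highest of the two numbers. Among the measured compounds shown here, the only measured step, a number 56 percentage points higher from compound 1 to compound 2 (beyond the scatter), came with carboxymethoxy in place of 3-carboxypropyl, showing that this side chain governs the response strongly. Compound 3 `Cc1nc(-c2ccc(C(F)(F)F)cc2)sc1CNc1ccc(CCC(=O)NC(C)C)cc1` changes that same chain: 2-(isopropylcarbamoyl)ethyl in place of carboxymethoxy on an aromatic carbon. Here the acid leaves altogether, a larger change than the measured step, so a large drop in this assay is expected, a number 80 percentage points lower from compound 2 to compound 3 (beyond the scatter). Compound 3 is estimated at 20%, within 0% to 60%.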

Compound 3, largest response reached (reported as percent of maximum), in percent of the reference or control that the assay uses: 84%
Compound 3: middle estimate off by 64 percentage points, on the low side, outside the stated range (above it).
By their numbers in this assay, from the lowest: compound 1; then compound 3; then compound 2.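

In this assay, swapping the acid chain of compound 2 for the amide chain costs only a modest part of the response (a number 16 percentage points lower from compound 2 to compound 3 (beyond the scatter)), so a carboxylic acid at this position is not needed for a high response. The amide chain also beats the acid chain of compound 1 (a number 40 percentage points higher from compound 1 to compound 3 (beyond the scatter)), so having an acid at this position does not by itself decide the response. Nothing at hand explains why this amide performs so well.

From the compounds shown here alone, whether the isopropyl group matters remains open, since a primary amide could show how much of the response depends on it. A tetrazole or an amine on the same chain would test how broadly this position tolerates change.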